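This account rests on a few compounds, and the source may have more. Where it says the series, first, only, none or still open, it means among the compounds named here.

Compound 3 `CC(C(=O)N1CCCc2ccccc21)N1CCN(S(=O)(=O)c2ccc(C(C)(C)C)cc2)CC1` carries the shared core of the series; compound 1 `CCN(CC)C(=O)C(C)N1CCN(S(=O)(=O)c2ccc(C(C)(C)C)cc2)CC1` and compound 2 `CC(C(=O)N1CC2CC2C1)N1CCN(S(=O)(=O)c2ccc(C(C)(C)C)cc2)CC1` differ from it only in the group on the carbonyl carbon. In an ADME assay on HepG2 cells (Homo sapiens) for inhibition, with a stated time of 48 h (on this read-out higher numbers stand for an effect only at larger amounts of compound and lower numbers for an effect already at smaller amounts), compound 3 gives > 40000 nM, which is a limit of the assay and not a number. In this assay compound 1 gives > 40000 nM, likewise a limit. In this assay compound 2 gives > 40000 nM, again a limit. Accordingly the steps a step that the two limits leave unreadable from compound 1 to compound 2, a step that the two limits leave unreadable from compound 1 to compound 3 and a step that the two limits leave unreadable from compound 2 to compound 3 cannot be read in size, since all three values sit at the limit of > 40000 nM in this assay, at which 3 of the 3 values shown sit. Compound 4 `CC(C(=O)N1CCc2ccccc2C1C)N1CCN(S(=O)(=O)c2ccc(C(C)(C)C)cc2)CC1` brings the change (1-methyl-1,2,3,4-tetrahydroisoquinolin-2-yl in place of 1,2,3,4-tetrahydroquinolin-1-yl on a carbonyl carbon). Every measured exchange of the group on the carbonyl carbon left the read-out at the limit, so for this change too no step beyond the scatter is expected in this assay, and the step that the limit leaves unreadable from compound 3 to compound 4 is itself only an estimate. For compound 4 the expected value in this assay is 60000 nM, with an estimated range from 30000 nM to 200000 nM, most probably reported once more as a limit.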

Compound 4, half-maximal effective concentration: 28000 nM
Beside the measured number, compound 4's estimate is 2.1-fold (0.33 log units) above it; measured number below the stated range.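

Compound 4 is the only one of the four compounds shown whose value in this assay is a number and not a limit, so a change of the group on the carbonyl carbon can bring the read-out into the measurable range. The steps are an at least 1.4-fold lower number from compound 3 to compound 4 (0.15 log units; that floor lies within the scatter), an at least 1.4-fold lower number from compound 2 to compound 4 (0.15 log units; that floor lies within the scatter) and an at least 1.4-fold lower number from compound 1 to compound 4 (0.15 log units; that floor lies within the scatter); each is a floor, and none shows a change beyond the scatter. Compound 1, compound 2 and compound 3 remain at a limit, and the steps among them cannot be read: the limit of > 40000 nM in this assay, at which 3 of the 4 values shown sit.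

Open, going by these compounds, is how large the true steps to compound 4 are. Also open, on these data alone, is whether the methyl group alone accounts for the number, which unsubstituted 1,2,3,4-tetrahydroisoquinolin-2-yl or an ethyl group in its place would test.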